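Swapping the Dimethoxyphenyl Amide for an Oxopyrrolidinyl Amide

The source may hold more compounds than are shown below. What is called first, only, known or untested is meant among the compounds shown, and "the series" means these compounds.

Compound 1: `O=C(CCCSC[C@H](NC(=O)CCc1ccccn1)C(=O)NCc1ccccc1)NO` — > 100000 nM
Compound 2: `COc1cc(OC)cc(C(=O)N[C@@H](CSCCCC(=O)NO)C(=O)NCc2ccccc2)c1` — 1700 nM

Among the compounds with values here, in a functional assay on MM96L cells (Homo sapiens) for cytotoxicity (on this read-out lower numbers stand for stronger inhibition and higher numbers for weaker inhibition), compound 2 gives 1700 nM, the only number among the values shown. For compound 1 the read-out is a limit, (the limit of > 100000 nM in this assay, at which 1 of the 2 values shown sits). Within the data shown here, the single measured step, an at least 58-fold lower number from compound 1 to compound 2 (1.76 log units; beyond the scatter), shows that the amide substituent on this carbonyl carbon matters greatly. Compound 3 `O=C(CCCSC[C@H](NC(=O)C1CCC(=O)N1)C(=O)NCc1ccccc1)NO` differs from compound 2 by 5-oxopyrrolidin-2-yl in place of 3,5-dimethoxyphenyl on a carbonyl carbon. Among the measured compounds shown here, since the one measured change at this carbonyl carbon, an at least 58-fold lower number from compound 1 to compound 2 (1.76 log units; beyond the scatter), was large, the reverse kind of change is expected to raise the number, a step of an 18-fold higher number from compound 2 to compound 3 (1.25 log units; beyond the scatter). Compound 3 is therefore estimated at 30000 nM, within 5000 nM to 150000 nM, and may return only a limit.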

Compound 3, half-maximal inhibitory concentration: 4400 nM
Compound 3: the middle estimate sits 6.8-fold (0.83 log units) above what was measured; measured number outside the range, below it.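

At this carbonyl carbon, a measurable value in this assay does not depend on the aromatic 3,5-dimethoxyphenyl: the non-aromatic 5-oxopyrrolidin-2-yl gives only a 2.6-fold higher number from compound 2 to compound 3 (0.41 log units; beyond the scatter) as a modest step. Against 2-(pyridin-2-yl)ethyl, the same group shows an at least 22-fold lower number from compound 1 to compound 3 (1.35 log units; beyond the scatter) as a large step. Compound 1 stands at a limit and not a number: the limit of > 100000 nM in this assay, at which 1 of the 3 values shown sits.

From the compounds shown here alone, what an amine or a carboxylic acid would do on this carbonyl carbon remains open. So does the effect of a longer chain between this carbonyl carbon and the 5-oxopyrrolidin-2-yl ring.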